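Switching the amide substituent in a cholesterol-synthesis inhibitor series

The source may report more compounds than this note shows. Statements on the series, on what has been measured and on what is new or still open speak of the compounds shown alone.

Compound 3 `CC(C)c1c(C(=O)NCc2ccccn2)nn(-c2ccc(F)cc2)c1OC[C@@H](O)C[C@@H](O)CC(=O)O`: 25 nM
Compound 1 `CC(C)c1c(C(=O)N(C)Cc2ccccc2)nn(-c2ccc(F)cc2)c1CC[C@@H](O)C[C@@H](O)CC(=O)O`: 6.2 nM
Compound 2 `CC(C)c1c(C(=O)N2CCC[C@H](c3ccccc3)C2)nn(-c2ccc(F)cc2)c1CC[C@@H](O)C[C@@H](O)CC(=O)O`: 2.1 nM

In an assay on microsomes from liver for inhibition of 3-hydroxy-3-methylglutaryl-coenzyme A reductase (Rattus norvegicus) (on this read-out higher numbers stand for weaker inhibition and lower numbers for stronger inhibition), compound 3 gives 25 nM, the highest of the three numbers; compound 1 gives 6.2 nM and compound 2 gives 2.1 nM. Compound 4 `CC(C)c1c(C(=O)N(C)Cc2cccc(Cl)c2)nn(-c2ccc(F)cc2)c1OC[C@@H](O)C[C@@H](O)CC(=O)O` differs from compound 3 by (3-chlorobenzyl)(methyl)amino in place of ((pyridin-2-yl)methyl)amino on a carbonyl carbon.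

Among the compounds with values here, the one measured step, a 3.0-fold lower number from compound 1 to compound 2 (0.47 log units; beyond the scatter), concerns a different change and a different core, so no step bears directly on this one. Compound 1, which carries benzyl(methyl)amino on a carbonyl carbon, and compound 3 differ in two places, so only their two values can be compared, and compound 1 shows the lower number.

On that basis compound 4 is expected to show a modest shift toward a lower number, a 2.5-fold lower number from compound 3 to compound 4 (0.40 log units; beyond the scatter). The estimated value for compound 4 in this assay is 10 nM, with a range from 3 nM to 35 nM.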

Compound 4, half-maximal inhibitory concentration: 8.3 nM
Compound 4: the middle estimate sits 1.2-fold (0.08 log units) above what was measured; measured number inside the range.
By their numbers in this assay, from the lowest: compound 2; then compounds 1 and 4 (each within the scatter of the next); then compound 3.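

On the core of compound 3, the group on the carbonyl carbon clearly affects the result in this assay: (3-chlorobenzyl)(methyl)amino in place of ((pyridin-2-yl)methyl)amino gives a 3.0-fold lower number from compound 3 to compound 4 (0.48 log units; beyond the scatter) and goes beyond the usual scatter. Within the data shown here, the earlier step at this carbonyl carbon involved a different change on the core of compound 1, so this is the first direct reading for this pair of groups on this core. The swap replaces the amide hydrogen with a methyl, the pyridine ring with a carbon-only ring, and adds a chlorine, and nothing available here explains why the number falls.

The compounds shown leave open which of these differences accounts for the step. Benzylamino or ((pyridin-2-yl)methyl)(methyl)amino on this core would help separate them.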